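A few compounds are considered here, and "the series" means these few. Any claim that something is new, unique, unknown or untested is made for them only; others in the source may bear on it.

The study concerns a small set of compounds built on a shared core, read in an assay on isolated protein for inhibition of phosphatidylinositol 4,5-bisphosphate 3-kinase catalytic subunit beta isoform (Homo sapiens), read by 33P incorporation, with a stated time of 60 min; a higher number here means a weaker inhibitor, a lower number a stronger inhibitor. Compound 1 `Cc1ccc([N+](=O)[O-])cc1S(=O)(=O)N(C)/N=C/c1cnn2cccc(Br)c12` and compound 2 `Cc1ccc([N+](=O)[O-])cc1S(=O)(=O)N(C)/N=C/c1cnn2c(C)cccc12` differ from one another in where and how the core is substituted, while compound 3 `Cc1ccc([N+](=O)[O-])cc1S(=O)(=O)N(C)/N=C/c1cnn2ccc(Br)cc12` carries a bromo group on the six-membered ring of the core. In this assay compound 1 reaches only the limit of the assay, > 1000 nM. Compound 2 likewise gives only a limit in this assay, > 1000 nM. For the measured compounds named here, compound 3 is the one compound with an actual number, giving 230 nM in this assay, so it stands alone among the values shown, the other two resting at the limit of > 1000 nM in this assay, at which 2 of the 3 values shown sit.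

Compound 4 `COC(=O)c1ccn2ncc(/C=N/N(C)S(=O)(=O)c3cc([N+](=O)[O-])ccc3C)c2c1` follows from compound 3 by methoxycarbonyl in place of bromo on an aromatic carbon. Going by the values given here, no pair of measured compounds shows this particular change, so there is no measured step to lean on. The expected change in this assay is a 1.7-fold higher number from compound 3 to compound 4 (0.24 log units; within the scatter), a step judged to be modest, if any, leaning toward a slight loss of potency rather than a gain. Compound 4 is estimated at 400 nM in this assay, with a range from 120 nM to 1500 nM.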

Compound 4, half-maximal inhibitory concentration: > 1000 nM
Compound 4 was reported as a limit; the forecaster's own chance of this, stated with the estimate: 25%; middle value at least 2.5-fold (0.39 log units) away from the limit.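

In this assay, the position opposite the ring nitrogen, which carries bromo in compound 3, turns out not to accept every replacement: methoxycarbonyl in place of bromo gives an at least 4.3-fold higher number from compound 3 to compound 4 (0.63 log units; beyond the scatter). For the compounds shown here, this is the first measured step in the set, and it shows that a change at this single aromatic carbon can move the result beyond the scatter, although the full size of the loss stays unknown since compound 4 reaches only a limit of the assay. Compound 3 therefore remains the only compound with an actual number, and the remaining values give no further scale for comparison: the limit of > 1000 nM in this assay, at which 3 of the 4 values shown sit.

The compounds shown leave open whether other groups at this position would keep or improve on the value of compound 3, such as chloro, methyl, a nitrile, an amine, the carboxylic acid or the primary amide. This single step also cannot separate the effect of the added heavy atoms from that of the hydrogen-bond acceptors that enter with methoxycarbonyl, so what drives the loss remains unresolved.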